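The source may hold more compounds than are shown below. What is called first, only, known or untested is meant among the compounds shown, and "the series" means these compounds.

Compound 2 `O=S(=O)(NCc1ccc2[nH]ccc2c1)c1ccccc1` is one of two compounds that have been examined in an assay on isolated protein for inhibition of Aromatase (Homo sapiens), read by fluorescence, with stated times of 10 min and 60 min, tested at 1 uM (a lower number here means less inhibition, a higher number more inhibition at the concentration tested (going by the name of the read-out)), where compound 2 gives 20.7%. Within the data shown here, its only companion is compound 1 `O=S(=O)(Cc1ccccc1)NCc1ccc2[nH]ccc2c1`, which in this assay gives 16.4%. Among the measured compounds shown here, the single step between the two, a number 4.3 percentage points higher from compound 1 to compound 2 (within the scatter), lies within the scatter, so compound 2 stands as the higher of the two numbers without being distinguishable from compound 1.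

Compound 3 `Cc1ccc(S(=O)(=O)NCc2ccc3[nH]ccc3c2)cc1` is the next member of the series and differs from compound 2 by methyl in place of hydrogen on an aromatic carbon. For the measured compounds named here, no measured step touches this kind of change: the one step on record concerns the group on the sulfonyl sulfur, not a substituent on the six-membered aromatic ring, and that step itself stayed within the scatter. Going by the values given here, nothing among the measured compounds therefore points to a step in this assay beyond the scatter in either direction. Compound 3 is accordingly expected to give 22%, with a range of 8% to 38%. The step this estimate means is a number 1.3 percentage points higher from compound 2 to compound 3 (within the scatter), expected to be small.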

Compound 3, a percentage reported as inhibition, at one concentration (the size of the read-out at that concentration, not a potency): 33.4%
Compound 3: the middle estimate sits 11.4 percentage points below what was measured; low and high end bracket the measured number.
By their numbers in this assay, from the lowest: compounds 1 and 2 (each within the scatter of the next); then compound 3.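

In this assay, among these compounds, methyl in place of hydrogen on an aromatic carbon, para to a large group, gives a number 12.7 percentage points higher from compound 2 to compound 3 (beyond the scatter) and so produces the first step in this short series that lies beyond the scatter, showing that this ring position can register a change in the read-out even though the earlier exchange of benzyl for phenyl did not. The comparison with the benzyl compound points the same way, with 4-methylphenyl in place of benzyl on a sulfonyl sulfur giving a number 17 percentage points higher from compound 1 to compound 3 (beyond the scatter) and leaving compound 3 as the highest of the three, with both of its steps beyond the scatter. Why the single added methyl has this effect cannot be said, as no supporting measurement bears on the result.

The compounds shown leave open whether the step belongs to methyl itself or would also appear with another group at this place, such as chlorine, methoxy, an amine or a carboxylic acid. They also leave open whether a longer chain such as ethyl or propyl would go further, and whether methyl at another place on the ring would give a step of similar size.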